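A Methoxy Step Carried From One Core to Another

This account rests on a few compounds, and the source may have more. Where it says the series, first, only, none or still open, it means among the compounds named here.

Compound 1, `C=C(Br)C(=O)Nc1ccc(C(=O)/C=C/c2ccc(OC)cc2OC)cc1`, gives 1500 nM in a functional assay on MOLT-4 cells (Homo sapiens) for antiproliferative activity, with a stated time of 48 h; a lower number here means a stronger inhibitor, a higher number a weaker inhibitor.
Compound 2, `C=C(Br)C(=O)Nc1ccc(C(=O)/C=C/c2ccc(OC)c(OC)c2OC)cc1`, gives 680 nM.
Compound 3, `Nc1ccc(C(=O)/C=C/c2ccccc2)cc1`, gives 7900 nM.

Compound 2 differs from compound 1 by methoxy in place of hydrogen on an aromatic carbon, and that change produced a 2.2-fold lower number from compound 1 to compound 2 (0.34 log units; beyond the scatter). Compound 3 has the highest number of the three measured; how its core differs from the core of compound 1 is not broken down here.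

Compound 4, `COc1ccccc1/C=C/C(=O)c1ccc(N)cc1`, has not yet been measured. It differs from compound 3 by methoxy in place of hydrogen on an aromatic carbon. The two places are not the same: in compound 2 the entering methoxy is ortho to two methoxy groups and meta to a large group, while in compound 4 it is ortho to a large group, so this is the same kind of change, not the same change. Among the measured compounds shown here, only one prior instance exists, and it sits on a different core.

The expectation rests on compound 3 giving 7900 nM and on the earlier step, a 2.2-fold lower number from compound 1 to compound 2 (0.34 log units; beyond the scatter). The expected step is a 1.6-fold lower number from compound 3 to compound 4 (0.20 log units; within the scatter), smaller than the earlier one. In this assay compound 4 is expected to give 5000 nM, with a range from 2000 nM to 15000 nM.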

Compound 4, half-maximal inhibitory concentration: 8300 nM
For compound 4 the middle estimate is 1.7-fold (0.22 log units) below the measured one; the measured number falls inside the stated range.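

In this assay the methoxy change on the core of compound 3 gives a 1.1-fold higher number from compound 3 to compound 4 (0.02 log units; within the scatter) and so stays within the usual scatter, whereas on the core of compound 1 the same kind of change went beyond it. Even so, the two steps cannot be told apart, since the gap between them is itself within the scatter expected of two such steps: the same change on two cores in this assay, a 2.2-fold lower number (0.34 log units; beyond the scatter) from compound 1 to compound 2 and a 1.1-fold higher number (0.02 log units; within the scatter) from compound 3 to compound 4, 2.3-fold (0.37 log units) apart, within the scatter of two such steps. This shows neither that the gain carries from one core to the other nor that it is lost, as each core offers a single pair and the methoxy enters at a different place on each, with the place in compound 4 being ortho to a large group, so core and place cannot be separated.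

The compounds shown leave open how a hydroxyl group, an ethoxy group or a chlorine atom would read at that same place on the core of compound 3. They also leave open whether a methoxy group elsewhere on that ring would behave as it did in compound 2.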